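Ester to acid on the side chain of compound 3

The source may report more compounds than this note shows. Statements on the series, on what has been measured and on what is new or still open speak of the compounds shown alone.

For the measured compounds named here, compound 3 `COC(=O)/C=C(\C)C[C@@H](OC(C)=O)[C@@]1(C)[C@H](C)CC=C2[C@@H]1CCCC2(C)C` is one of three compounds so far examined in a functional assay on U-937 cells (Homo sapiens) for cytotoxicity, read by MTT assay, with a stated time of 72 h; a higher number here means a weaker inhibitor, a lower number a stronger inhibitor. In this assay compound 3 gives > 30000 nM, which is a limit of the assay and not a number. Compound 1 `CC(=O)O[C@H](C/C(C)=C/CO)[C@@]1(C)[C@H](C)CC=C2[C@@H]1CCCC2(C)C` likewise reaches only a limit in this assay, at > 30000 nM. Compound 2 `CCCC(=O)OC/C=C(\C)C[C@@H](O)[C@@]1(C)[C@H](C)CC=C2[C@@H]1CCCC2(C)C` also reaches only a limit in this assay, at > 30000 nM. Going by the values given here, the one measured step that differs in a single place, a step that the two limits leave unreadable from compound 1 to compound 3, cannot be read in size, since both of its ends sit at the limit (the limit of > 30000 nM in this assay, at which 3 of the 3 values shown sit). Compound 4 `CC(=O)O[C@H](C/C(C)=C/C(=O)O)[C@@]1(C)[C@H](C)CC=C2[C@@H]1CCCC2(C)C` differs from compound 3 by hydrogen in place of methyl on an oxygen next to a carbonyl group. Among the compounds with values here, no measured step bears directly on this change, and the only step available leaves its size unreadable. Within the data shown here, with every value so far sitting at the limit (the limit of > 30000 nM in this assay, at which 3 of the 3 values shown sit), no movement beyond the scatter is expected in this assay, and the most likely outcome for compound 4 is again a limit rather than a number. Compound 4 is therefore estimated at 30000 nM, between 10000 nM and 100000 nM. The step this estimate means, a number no higher from compound 3 to compound 4 (the limit leaves the size open), is expected to be nil within the scatter.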

Compound 4, half-maximal inhibitory concentration: > 30000 nM
Compound 4: no number, only a limit; the forecaster's own chance of this, stated with the estimate: 85%; the middle value lies on the limit itself.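

No step can be read from compound 3 to compound 4 or from compound 1 to compound 4, because both ends of each are limits and not numbers: the limit of > 30000 nM in this assay, at which 4 of the 4 values shown sit.

The compounds shown leave open whether any change among them moves the read-out in this assay.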